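Open-chain pentyl replacing the cycloalkyl thioether

The compounds below may be only part of what the source reports. "The series", "measured", "known", "first", "only" and "open" are said of these compounds alone.

Compound 2 `CC(C(=O)NCc1ccc(C(C)(C)C)cc1SC1CCCCC1)c1ccc(NS(C)(=O)=O)c(F)c1` gives 7.4 nM in an assay on cells for antagonist activity at transient receptor potential cation channel subfamily V member 1 (Homo sapiens), read by FLIPR and calcium flux, with a stated time of 6 min (a lower number here means a stronger inhibitor, a higher number a weaker inhibitor), the higher of the two numbers recorded so far; its nearest neighbour is compound 1 `CC(C(=O)NCc1ccc(C(C)(C)C)cc1OC1CCCC1)c1ccc(NS(C)(=O)=O)c(F)c1`, which gives 1.8 nM in this assay. Among the measured compounds shown here, the single measured step, a 4.1-fold higher number from compound 1 to compound 2 (0.61 log units; beyond the scatter), connects these two. The next compound, compound 3 `CCCCCc1cc(C(C)(C)C)ccc1CNC(=O)C(C)c1ccc(NS(C)(=O)=O)c(F)c1`, differs from compound 2 in one place: pentyl in place of cyclohexylsulfanyl on an aromatic carbon. For the measured compounds named here, no measured step bears directly on this exchange; the only recorded step changes the ring and the linking atom at once, so it offers no guide to an open chain without a linking atom. With no supporting data, the step is expected to stay within the scatter or to run slightly toward a higher number, so that compound 3 is estimated at 10 nM in this assay, between 3 nM and 35 nM, corresponding to an expected step of a 1.4-fold higher number from compound 2 to compound 3 (0.13 log units; within the scatter).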

Compound 3, inhibition constant: 2.8 nM
Compound 3: middle estimate off by 3.6-fold (0.55 log units), on the high side; the measured number lies below the stated range.
By their numbers in this assay, from the lowest: compounds 1 and 3 (each within the scatter of the next); then compound 2.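

In this assay, the aromatic carbon ortho to a large group and meta to a tert-butyl group accepts an open chain attached directly, with no ring and no linking atom: pentyl in place of cyclohexylsulfanyl gives a 2.6-fold lower number from compound 2 to compound 3 (0.42 log units; beyond the scatter). Pentyl in place of cyclopentyloxy gives a 1.6-fold higher number from compound 1 to compound 3 (0.19 log units; within the scatter), so in these compounds neither the ring nor the linking oxygen is needed for a number at the level of compound 1. The data offer no explanation for either step.

As far as these compounds go, the step from compound 2 to compound 3 changes ring and linking sulfur together, so their separate contributions remain open; a directly attached cyclohexyl or a pentylsulfanyl chain would separate them. From the compounds shown here alone, how chain length reads at this position also remains open, for example with propyl or heptyl.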